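Swapping iodo for methylsulfanyl on the shared core

The source may report more compounds than this note shows. Statements on the series, on what has been measured and on what is new or still open speak of the compounds shown alone.

Compound 2 `N#Cc1cc(C(=O)N2CC=CC2)cc(I)c1O` gives the higher of the two measured numbers in an assay on isolated protein for inhibition of solute carrier family 22 member 12 (Homo sapiens), tested at 3 uM (a higher number here means more inhibition at the concentration tested (going by the name of the read-out), a lower number less inhibition), where compound 2 gives 79%. Its neighbour compound 1 `CCc1cc(C(=O)N2CC=CC2)cc(C#N)c1O` carries ethyl where compound 2 carries iodo. In this assay compound 1 gives 54%, and the step of a number 25 percentage points higher from compound 1 to compound 2 (beyond the scatter) is the only measured one that bears on the present question. Compound 3 `CSc1cc(C(=O)N2CC=CC2)cc(C#N)c1O` differs from compound 2 in one place: methylsulfanyl in place of iodo on an aromatic carbon, on an aromatic carbon ortho to a hydroxy group and meta to a cyano group. Among the measured compounds shown here, the one measured step shows that the group at this position matters, and that the inhibition moves by a modest amount when iodo is present rather than ethyl. For the measured compounds named here, no measured step pairs iodo with methylsulfanyl, so the direction is uncertain; a drop is expected, estimated as a number 17 percentage points lower from compound 2 to compound 3 (beyond the scatter). Compound 3 is therefore expected to give about 62%, within 40% to 80%.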

Compound 3, a percentage reported as inhibition, at one concentration (the size of the read-out at that concentration, not a potency): 58%
Compound 3: middle estimate off by 4 percentage points, on the high side, within the range that was stated.
By their numbers in this assay, from the lowest: compounds 1 and 3 (each within the scatter of the next); then compound 2.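

In this assay the change to methylsulfanyl in place of iodo is a number 21 percentage points lower from compound 2 to compound 3 (beyond the scatter) on this aromatic carbon, ortho to a hydroxy group and meta to a cyano group, so a second group now falls short of iodo. The change to methylsulfanyl in place of ethyl is a number 4 percentage points higher from compound 1 to compound 3 (within the scatter) and does not separate these two groups, which leaves iodo as the only one of the three that stands apart at this position. Nothing available here accounts for the gap between iodo and the other two groups.

Whether iodo's edge is particular to iodine remains open, since neither bromo nor chloro appears among these compounds. On these data alone, how an amine, a carboxylic acid or a longer chain than ethyl would fare at this position also remains unknown.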